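The compounds below may be only part of what the source reports. "The series", "measured", "known", "first", "only" and "open" are said of these compounds alone.

Measured so far:
compound 1 `CC(=O)c1cc(C(C)=O)c(OCCCCC#N)cc1O` — 0%
compound 2 `C=CCc1cc(C(C)=O)c(O)cc1OCC#N` — 2%

In an assay on isolated protein for binding affinity to leukotriene B4 receptor 1 (Homo sapiens), tested at 1 uM (on this read-out lower numbers stand for less inhibition and higher numbers for more inhibition at the one concentration tested (going by the name of the read-out)), compound 1 gives 0% and compound 2 gives 2%; the two numbers lie within the usual scatter of each other, so neither shows inhibition at this concentration. Compound 3 `C=CCc1cc(C(C)=O)c(O)cc1OCCCCCC#N` is not yet measured. It differs from compound 2 by 4-cyanobutyl in place of cyano on a saturated chain carbon bound to an oxygen on an aromatic ring. For the measured compounds named here, no step between measured compounds covers this change. Compound 1 also bears a nitrile on such a chain and in this assay gives 0%. The step of a number 1 percentage points higher from compound 2 to compound 3 (within the scatter) is therefore expected to stay within the scatter, with no direction. Compound 3 is expected to give 3%, in the range 0% to 15%.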

Compound 3, a percentage reported as inhibition, at one concentration (the size of the read-out at that concentration, not a potency): 41%
The estimate for compound 3 lay 38 percentage points below the measured number, outside the stated range (above it).
By their numbers in this assay, from the lowest: compounds 1 and 2 (each within the scatter of the next); then compound 3.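

For the compounds shown here, with 4-cyanobutyl in place of cyano on a saturated chain carbon bound to an oxygen on an aromatic ring, this assay shows a number 39 percentage points higher from compound 2 to compound 3 (beyond the scatter) as the only step. This position therefore responds to what links the nitrile to the oxygen, which compound 1 and compound 2 alone could not show. Nothing at hand accounts for the size of this step.

Open, as far as these compounds go, is whether a longer chain carrying the nitrile goes further on this read-out. Also open, from the compounds shown here alone, is whether the nitrile itself matters, which a carboxylic acid or an amine at the chain end would test.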